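This account rests on a few compounds, and the source may have more. Where it says the series, first, only, none or still open, it means among the compounds named here.

Compound 1 `Cc1ccc(-c2ccnc(C(=O)Nc3ccc(Oc4ccnc5[nH]ccc45)cc3)c2)cc1` gives in a functional assay on A549 cells (Homo sapiens) for cytotoxicity, read by MTT assay, with a stated time of 72 h (on this read-out higher numbers stand for weaker inhibition and lower numbers for stronger inhibition), only a limit, > 10000 nM.
Compound 2 `O=C(Nc1ccc(Oc2ccnc3[nH]ccc23)cc1)c1cc(-c2ccc(Cl)cc2)ccn1` gives in this assay 4310 nM.
Compound 3 `Cc1cccc(-c2ccnc(C(=O)Nc3ccc(Oc4ccnc5[nH]ccc45)cc3)c2)c1` gives in this assay 7010 nM.

Going by the values given here, compound 2 and compound 3 are the only two with actual numbers, and their gap, a 1.6-fold higher number from compound 2 to compound 3 (0.21 log units; within the scatter), lies within the scatter, so neither stands apart from the other. Compound 4 `Cc1cccc(-c2ccnc(C(=O)Nc3ccc(Oc4ccnc5[nH]ccc45)c(F)c3)c2)c1` differs from compound 3 by fluoro in place of hydrogen on an aromatic carbon. The measured steps all concern the methyl- or chlorophenyl group on the far end of the molecule: an at least 2.3-fold lower number from compound 1 to compound 2 (0.36 log units; beyond the scatter) and an at least 1.4-fold lower number from compound 1 to compound 3 (0.15 log units; that floor lies within the scatter), the latter resting on a limit (the limit of > 10000 nM in this assay, at which 1 of the 3 values shown sits). None of them touches the ring that gains the fluoro, so they offer no direct guide. For compound 4 the expected step is therefore a 1.1-fold lower number from compound 3 to compound 4 (0.03 log units; within the scatter), nothing beyond the scatter. Compound 4 is estimated at 6500 nM, between 2500 nM and 20000 nM.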

Compound 4, half-maximal inhibitory concentration: 1750 nM
The estimate for compound 4 lay 3.7-fold (0.57 log units) above the measured number; the whole stated range lies above it.
By their numbers in this assay, from the lowest: compound 4; then compounds 2 and 3 (each within the scatter of the next). At a limit, above all of these: compound 1.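

The ring left unchanged across compound 1, compound 2 and compound 3 turns out to matter in this assay: fluoro in place of hydrogen on an aromatic carbon, ortho to a large group and meta to a large group, gives a 4.0-fold lower number from compound 3 to compound 4 (0.60 log units; beyond the scatter). So a change of one heavy atom on this ring moves the number beyond the scatter, which the earlier changes at the far end could not show. Nothing measured here explains this step.

As far as these compounds go, whether an amine or a methoxy group at this place would act like fluoro remains open. So does whether fluoro would give a similar step alongside the 4-chlorophenyl group of compound 2.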